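Swapping chloro for dimethylamino on an amide side chain

The source may report more compounds than this note shows. Statements on the series, on what has been measured and on what is new or still open speak of the compounds shown alone.

Among the compounds with values here, compound 2 `COc1ncc(-c2ccc3ncnc(N[C@H]4CCCN(C(=O)CCl)C4)c3c2)cc1C#N` gives 380 nM in a functional assay on SU-DHL-6 cells (Homo sapiens) for antiproliferative activity, read by MTT assay (on this read-out higher numbers stand for weaker inhibition and lower numbers for stronger inhibition), the higher of the two numbers so far; its nearest neighbour is compound 1 `COc1ncc(-c2ccc3ncnc(N[C@H]4CCCN(C(=O)C5CCOCC5)C4)c3c2)cc1C#N`, which gives 150 nM. Within the data shown here, the one measured step, a 2.5-fold higher number from compound 1 to compound 2 (0.40 log units; beyond the scatter), alters the group on the carbonyl carbon. Compound 3 `COc1ncc(-c2ccc3ncnc(N[C@H]4CCCN(C(=O)CN(C)C)C4)c3c2)cc1C#N` changes that side chain again: dimethylamino in place of chloro on a saturated chain carbon bound to a carbonyl carbon. Among the measured compounds shown here, no measured step shows this change, so the only guide is that the earlier change at the same carbonyl was modest. Compound 3 is therefore expected near compound 2, with a 1.2-fold higher number from compound 2 to compound 3 (0.07 log units; within the scatter), giving an estimated 450 nM within 150 nM to 1400 nM.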

Compound 3, half-maximal inhibitory concentration: 160 nM
Beside the measured number, compound 3's estimate is 2.8-fold (0.45 log units) above it, within the range that was stated.
By their numbers in this assay, from the lowest: compounds 1 and 3 (each within the scatter of the next); then compound 2.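

Dimethylamino in place of chloro on a saturated chain carbon bound to a carbonyl carbon brings a 2.4-fold lower number from compound 2 to compound 3 (0.38 log units; beyond the scatter) in this assay and shows that this small side chain can move the number beyond the scatter. The comparison with the earlier amide gives a 1.1-fold higher number from compound 1 to compound 3 (0.03 log units; within the scatter) and so shows that (dimethylamino)methyl and oxan-4-yl on a carbonyl carbon cannot be told apart here. Chloro is thus the only one of these three groups that stands apart.

From the compounds shown here alone, whether a longer chain ending in dimethylamino, or a carboxylic acid on that chain carbon, would give a similar number stays open. What lies behind these differences also stays open, as no supporting measurement bears on them.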